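This account rests on a few compounds, and the source may have more. Where it says the series, first, only, none or still open, it means among the compounds named here.

Measured compounds:

Compound 1, `COC(C(=O)OC(C)Cn1cnc2c1c(=O)n(C)c(=O)n2C)c1cccc2ccccc12`: in a functional assay on CCRF-CEM cells (Homo sapiens) for antiproliferative activity, read by MTT assay, with a stated time of 72 h, tested at 200 uM (on this read-out higher numbers stand for a weaker effect at the one concentration tested and lower numbers for a stronger effect), compound 1 gives 34.6%.
Compound 2, `CC(Cn1cnc2c1c(=O)n(C)c(=O)n2C)OC(=O)CC(=O)c1ccc(F)cc1`: in this assay compound 2 gives 20.1%.

Of the two numbers shown, compound 2 has the lowest, standing below compound 1 by a gap that lies beyond the usual scatter of this read-out, and so on this measure compound 2 shows the stronger effect at the single concentration tested. The two compounds are not linked by any single-point change, so nothing can be said of what separates them beyond what the two values themselves show.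

Compound 3, `Cc1ccc(C(=O)CC(=O)OC(C)Cn2cnc3c2c(=O)n(C)c(=O)n3C)cc1`, has not yet been measured in this assay. It differs from compound 2 in one place: methyl in place of fluoro on an aromatic carbon. Among the measured compounds shown here, no measured pair in this set shows the effect of such a swap, so there is no step to lean on. The expectation is that the change from compound 2 to compound 3 is small, a number 5.9 percentage points higher from compound 2 to compound 3 (within the scatter), with no direction that can be trusted beyond the scatter. For compound 3 the estimated value in this assay is 26%, within a range from 12% to 42%.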

Compound 3, a percentage reported as activity, at one concentration (the size of the read-out at that concentration, not a potency): 31.6%
Compound 3: the middle estimate sits 5.6 percentage points below what was measured; the range from low to high includes it.
By their numbers in this assay, from the lowest: compound 2; then compounds 3 and 1 (each within the scatter of the next).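

Among the compounds shown here, the swap of fluoro for methyl, read as 4-fluorophenyl to 4-methylphenyl, is the first single-point change in the set, and in this assay it gives a number 11.5 percentage points higher from compound 2 to compound 3 (beyond the scatter), a modest step. It shows that this place on the aromatic ring, para to a large group, is not silent: exchanging one heavy atom for another, with no change in the count of hydrogen-bond donors or acceptors and no net charge, shifts the read-out towards a weaker effect at the single concentration tested. Nothing at hand explains why the step runs in this direction.

The compounds shown leave open how a chloro group, a methoxy group, an amine or a carboxylic acid would read at this same place, and whether a phenyl ring with only hydrogen there would fall nearer to compound 2 or to compound 3. They also leave open whether the same exchange would give a step of similar size on another part of the series, as the finding rests on one pair at one concentration.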